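A few compounds are considered here, and "the series" means these few. Any claim that something is new, unique, unknown or untested is made for them only; others in the source may bear on it.

Measured in an ADME assay on L1210/0 cells (Mus musculus) for cytotoxicity, with a stated time of 48 h; a higher number here means a weaker inhibitor, a lower number a stronger inhibitor:
- compound 1 `O=c1[nH]c(=O)n([C@H]2C[C@H](O)[C@@H](CO)O2)cc1/C=C/I`: 63900 nM
- compound 2 `C=C(Cl)c1cn([C@H]2C[C@H](O)[C@@H](CO)O2)c(=O)[nH]c1=O`: 1660 nM
- compound 3 `COCC#Cc1cn([C@H]2C[C@H](O)[C@@H](CO)O2)c(=O)[nH]c1=O`: > 200000 nM

For compound 3, > 200000 nM is a limit of the assay and not a number. It gives compound 3 no exact place, though its steps from the other two compounds are both beyond the scatter.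

The next compound is compound 4 `C[S+]([O-])c1cn([C@H]2C[C@H](O)[C@@H](CO)O2)c(=O)[nH]c1=O`. The change is a group of 3 heavy atoms (1 carbon, 1 oxygen, 1 sulfur; no ring) in place of a group of 5 heavy atoms (4 carbon, 1 oxygen; no ring), on an aromatic carbon, with the 3-methoxyprop-1-yn-1-yl group leaving.

All three measured steps are swaps on this same aromatic carbon, and none involves the entering group. They are a 38-fold lower number from compound 1 to compound 2 (1.59 log units; beyond the scatter), an at least 3.1-fold higher number from compound 1 to compound 3 (0.49 log units; beyond the scatter) and an at least 120-fold higher number from compound 2 to compound 3 (2.08 log units; beyond the scatter). Substitution here can therefore move this assay a long way in these compounds, but the direction for the new group cannot be read from them, so the range has to stay wide.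

The closest guide is the weak end of the series, and a result near the limit is expected. The expected step is an at least 1.6-fold lower number from compound 3 to compound 4 (0.22 log units; that floor lies within the scatter), with nothing clearly beyond the scatter anticipated. For compound 4 the estimated value is 120000 nM, with an expected range of 20000 nM to 300000 nM.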

Compound 4, half-maximal inhibitory concentration: > 200000 nM
Compound 4: a limit, no number; the forecaster's own chance of this, stated with the estimate: 55%; middle value at least 1.6-fold (0.22 log units) from the limit.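

In this assay compound 4 gives > 200000 nM, which is a limit of the assay and not a number. On this aromatic carbon, the group of 3 heavy atoms gives an at least 120-fold higher number from compound 2 to compound 4 (2.08 log units; beyond the scatter) and an at least 3.1-fold higher number from compound 1 to compound 4 (0.49 log units; beyond the scatter), so a second group, alongside 3-methoxyprop-1-yn-1-yl, now stands clear of both ethenyl compounds. The step between compound 3 and compound 4 cannot be read, because both sit at the same ceiling: the limit of > 200000 nM in this assay, at which 2 of the 4 values shown sit.

From the compounds shown here alone, how far compound 3 and compound 4 lie past that limit stays unknown, so the two groups cannot be ordered. Also open, going by these compounds, is where an amine, a carboxylic acid or a longer alkyl chain on this carbon would fall, including whether any of them would give a lower number than the 1-chloroethenyl group of compound 2.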